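Amide replaced by amine on the side chain of compound 1

A few compounds are considered here, and "the series" means these few. Any claim that something is new, unique, unknown or untested is made for them only; others in the source may bear on it.

Compound 1 `NC(=O)Cc1cc(=O)oc2cc(OCc3ccccc3)ccc12` gives 200 nM in an assay for inhibition of Amine oxidase [flavin-containing] B (Rattus norvegicus) (on this read-out higher numbers stand for weaker inhibition and lower numbers for stronger inhibition), and stands second highest of the three numbers: compound 2 `NC(=O)Cc1cc(=O)oc2cc(OCc3cccc(Cl)c3)ccc12` gives 30 nM, and compound 3 `NC(=O)Cc1cc(=O)oc2cc(OCc3cccnc3)ccc12` gives 1300 nM. The steps measured so far, a 6.7-fold lower number from compound 1 to compound 2 (0.82 log units; beyond the scatter), a 6.5-fold higher number from compound 1 to compound 3 (0.81 log units; beyond the scatter) and a 43-fold higher number from compound 2 to compound 3 (1.64 log units; beyond the scatter), all change the group on the saturated chain carbon bound to an oxygen on the aromatic ring. Compound 4 `NCc1cc(=O)oc2cc(OCc3ccccc3)ccc12` differs from compound 1 at another place: amino in place of carbamoyl on a saturated chain carbon bound to an aromatic carbon. For the measured compounds named here, no measured step touches that part of the shared core, so neither size nor direction of the change in this assay can be read from the data. For compound 4 a step within or somewhat beyond the scatter is expected, a 2.0-fold higher number from compound 1 to compound 4 (0.30 log units; within the scatter). Compound 4 is estimated at 400 nM, between 80 nM and 2500 nM.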

Compound 4, half-maximal inhibitory concentration: 21 nM
For compound 4 the middle estimate is 19-fold (1.28 log units) above the measured one, and the stated range ends above it.
By their numbers in this assay, from the lowest: compounds 4 and 2 (each within the scatter of the next); then compound 1; then compound 3.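

Swapping carbamoyl for amino on the saturated chain carbon bound to an aromatic carbon gives a 9.5-fold lower number from compound 1 to compound 4 (0.98 log units; beyond the scatter) in this assay. For the compounds shown here, this place on the shared core, untouched by the earlier steps, therefore also moves the read-out, here towards stronger inhibition. The carbamoyl group is not required for inhibition on the core of compound 1, and nothing measured here explains this step.

Still open, as far as these compounds go, is how a carboxylic acid or a longer chain such as aminoethyl would read at this place. Also open, from the compounds shown here alone, is whether aminomethyl and the 3-chlorophenyl group of compound 2 would combine additively in one molecule.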